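Amine for ether on the shared core: compound 4

The source may report more compounds than this note shows. Statements on the series, on what has been measured and on what is new or still open speak of the compounds shown alone.

Of the compounds shown here, three on one core have been measured in a functional assay on SW-620 cells (Homo sapiens) for inhibition, read by sulforhodamine B assay, with a stated time of 48 h; on this read-out lower numbers stand for stronger inhibition of growth and higher numbers for weaker inhibition of growth. Compound 1, `Nc1cc(N)c2nc(-c3ccccc3)c(Oc3ccc(F)cc3)nc2c1`, gives 19500 nM. Compound 2, `COc1cc(CNc2nc3cc(N)cc(N)c3nc2-c2ccccc2)cc(OC)c1OC`, gives 1550 nM, and compound 3, `CCOC(=O)[C@H](CCC(=O)O)NC(=O)c1ccc(Oc2nc3cc(N)cc(N)c3nc2-c2ccccc2)cc1`, gives 29500 nM. Compound 1 stands second highest of the three numbers: its gap to compound 3 is within the usual scatter, while compound 2 sits well below it, beyond the scatter.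

Compound 4, `Nc1cc(N)c2nc(-c3ccccc3)c(NCc3ccc(F)cc3)nc2c1`, is not yet measured. It differs from compound 1 in one place, ((4-fluorobenzyl)amino in place of 4-fluorophenoxy on an aromatic carbon), on an aromatic carbon next to the ring nitrogen and ortho to the phenyl group of the core. Among the measured compounds shown here, compound 2 is the only measured compound that carries an amino link of this kind to a benzyl group, and its value of 1550 nM is the lowest of the set.

On that basis the step of a 5.6-fold lower number from compound 1 to compound 4 (0.75 log units; beyond the scatter) is expected to run downward, beyond the scatter. Compound 4 is estimated at 3500 nM, with a range from 1000 nM to 12000 nM.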

Compound 4, concentration for 50% growth inhibition: 2190 nM
The estimate for compound 4 lay 1.6-fold (0.20 log units) above the measured number; measured number inside the range.
By their numbers in this assay, from the lowest: compounds 2 and 4 (each within the scatter of the next); then compounds 1 and 3 (each within the scatter of the next).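

In this assay, (4-fluorobenzyl)amino in place of 4-fluorophenoxy on the aromatic carbon next to the ring nitrogen gives an 8.9-fold lower number from compound 1 to compound 4 (0.95 log units; beyond the scatter). Among the compounds shown here, this is the first one-place comparison, and it shows that the number at this position moves beyond the scatter with the group attached there. The entering group brings a hydrogen-bond donor that the leaving group lacks, but no measurement here ties the step to that difference or to any other cause.

The exchange alters the link atom and adds a methylene together, so the compounds shown cannot assign the step to either. A phenylamino or a benzyloxy group on this carbon would separate the two, and a longer chain between the amine and the fluorophenyl ring would test the spacing.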